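The compounds below may be only part of what the source reports. "The series", "measured", "known", "first", "only" and "open" are said of these compounds alone.

Compound 1 `COc1cccc(OC)c1OCCNCCOc1ccccc1OCc1ccc(Cl)cc1`: 0.251 nM in an assay on CHO cells for displacement of a labelled ligand from Alpha-1A adrenergic receptor (Homo sapiens); on this read-out higher numbers stand for weaker inhibition and lower numbers for stronger inhibition
Compound 2 `COc1cccc(OC)c1OCCNCCOc1ccccc1OCc1ccccc1[N+](=O)[O-]`: 7.94 nM
Compound 3 `COc1cccc(OC)c1OCCNCCOc1ccccc1OCc1ccc([N+](=O)[O-])cc1`: 1.26 nM

Compound 1 gives the lowest number of the three in this assay. The nearest is compound 3, reached by a 5.0-fold higher number from compound 1 to compound 3 (0.70 log units; beyond the scatter), and the furthest is compound 2, reached by a 32-fold higher number from compound 1 to compound 2 (1.50 log units; beyond the scatter). Between those two nitro compounds the step is a 6.3-fold lower number from compound 2 to compound 3 (0.80 log units; beyond the scatter).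

Compound 4 `COc1ccccc1COc1ccccc1OCCNCCOc1c(OC)cccc1OC` has not yet been measured. It differs from compound 1 by 2-methoxyphenyl in place of 4-chlorophenyl on a saturated chain carbon bound to an oxygen on an aromatic ring. Among the compounds with values here, two measured steps bear on this. The step from compound 1 to compound 2 also replaces the 4-chlorophenyl with a phenyl carrying a single group at the position named in the group's name, and it was large. The step from compound 1 to compound 3 keeps the position but changes the group, and it was modest. Within the data shown here, compound 4 shares the placement of its group with compound 2 but carries methoxy rather than nitro, and no measured pair separates those two groups. A loss against compound 1 is therefore expected, smaller than that of compound 2 and likely nearer that of compound 3, so compound 4 is estimated at 2.5 nM, between 0.6 nM and 10 nM, which means an expected step of a 10-fold higher number from compound 1 to compound 4 (1.00 log units; beyond the scatter).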

Compound 4, inhibition constant: 2 nM
Estimate against measurement, compound 4: 1.3-fold (0.10 log units) above; the measured number falls inside the stated range.
By their numbers in this assay, from the lowest: compound 1; then compounds 3 and 4 (each within the scatter of the next); then compound 2.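

In this assay, 2-methoxyphenyl on this saturated chain carbon gives an 8.0-fold higher number from compound 1 to compound 4 (0.90 log units; beyond the scatter), so a third replacement for the 4-chlorophenyl also fails to match compound 1, which keeps the lowest number of the four. Within the data shown here, the step of a 4.0-fold lower number from compound 2 to compound 4 (0.60 log units; beyond the scatter) is the first measured comparison of methoxy with nitro on an aromatic carbon, and it shows that the high number of compound 2 does not follow from the placement in the group's name alone, since 2-methoxyphenyl and 2-nitrophenyl give clearly different numbers. The step of a 1.6-fold higher number from compound 3 to compound 4 (0.20 log units; within the scatter) leaves 2-methoxyphenyl and 4-nitrophenyl indistinguishable here, even though the two differ in both group and placement; nothing in the data given accounts for any of these differences.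

The compounds shown leave open how much of the gap to compound 1 comes from the group and how much from its placement, a question that a 4-methoxyphenyl and a 2-chlorophenyl at this place would address. Also open, going by these compounds, is how an unsubstituted phenyl, or a phenyl carrying an amine or a carboxylic acid, would compare with the 4-chlorophenyl of compound 1.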